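The source may report more compounds than this note shows. Statements on the series, on what has been measured and on what is new or still open speak of the compounds shown alone.

Measured compounds in an ADME assay on HEK293 cells (Homo sapiens) for cytotoxicity, with a stated time of 72 h; on this read-out lower numbers stand for an effect already at smaller amounts and higher numbers for an effect only at larger amounts of compound:
compound 1 `Cc1cc(NC(=O)Nc2ccccc2C(F)(F)F)c2ccccc2n1`: > 25000 nM
compound 2 `Cc1cc(NC(=O)Nc2cc(Cl)cc(Cl)c2)c2ccccc2n1`: > 25000 nM
compound 3 `COC(=O)c1cccc(NC(=O)Nc2cc(C)nc3ccccc23)c1`: 26000 nM

The value of compound 1 in this assay is a limit of the assay, not a number. The value of compound 2 in this assay is likewise a limit. Compound 3 gives 26000 nM in this assay. Among the compounds with values here, compound 1 thus stands at the limit of > 25000 nM in this assay, at which 2 of the 3 values shown sit, and no step between two measured compounds is available, since none of the three differs from another in just one place.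

Compound 4 `COc1ccccc1NC(=O)Nc1cc(C)nc2ccccc12` is still to be measured in this assay. It differs from compound 1 by methoxy in place of trifluoromethyl on an aromatic carbon. The three measured compounds, which differ from one another only in groups away from the shared core, give values that are not separated beyond the scatter, and no cause for this can be pointed to. The expected step of a number no higher from compound 1 to compound 4 (the limit leaves the size open) is therefore none beyond the scatter. Compound 4 is expected at 25000 nM, with a range from 10000 nM to 60000 nM, and a limit rather than a number is the more likely outcome.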

Compound 4, half-maximal effective concentration: > 25000 nM
Compound 4 was reported as a limit; the forecaster's own chance of this, stated with the estimate: 70%; the middle value lies on the limit itself.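

Within the data shown here, compound 1 and compound 4 are both reported as limits, not numbers, in this assay, and no step between them can be read. The compounds shown leave open whether methoxy in place of trifluoromethyl on an aromatic carbon changes this read-out at all.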